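Taking the Acetyl off Compound 2

The compounds below may be only part of what the source reports. "The series", "measured", "known", "first", "only" and "open" are said of these compounds alone.

Compound 1, `COc1cc(-c2ccnc3c(-c4ccc(C)cc4)cnn23)cc(OC)c1OC`: > 10000 nM, a limit of the assay.
Compound 2, `COc1cc(-c2ccnc3cc(-c4ccc(C(C)=O)cc4)nn23)cc(OC)c1OC`: 4390 nM.
Compound 3, `Cc1ccc(-c2cc3nccc(-c4ccc(F)cc4)n3n2)cc1`: > 10000 nM, a limit of the assay.

Going by the values given here, in a functional assay on HCT-116 cells (Homo sapiens) for inhibition, read by CCK-8 assay, with a stated time of 48 h (on this read-out lower numbers stand for stronger inhibition and higher numbers for weaker inhibition), compound 2 gives 4390 nM, and it is the only one of the three compounds for which a number rather than a limit is reported. For compound 1 the assay reports only a limit. For compound 3 it likewise reports only a limit. Two of the three values therefore sit at the limit of > 10000 nM in this assay, at which 2 of the 3 values shown sit, and compound 2 stands alone as the measured point.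

Compound 4, `COc1cc(-c2ccnc3cc(-c4ccccc4)nn23)cc(OC)c1OC`, differs from compound 2 in one place: hydrogen in place of acetyl on an aromatic carbon. Among the compounds with values here, no step between measured compounds is available to calibrate this change, so its size can only be guessed. He expects a modest move toward weaker inhibition, a 1.8-fold higher number from compound 2 to compound 4 (0.26 log units; within the scatter), estimating compound 4 at 8000 nM with a range from 3000 nM to 20000 nM, since the two compounds without a number, compound 1 and compound 3, sit at the limit of > 10000 nM in this assay, at which 2 of the 3 values shown sit.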

Compound 4, half-maximal inhibitory concentration: 3880 nM
The estimate for compound 4 lay 2.1-fold (0.31 log units) above the measured number; measured number inside the range.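

In this assay, going by these compounds alone, the step from the 4-acetylphenyl group to phenyl is a 1.1-fold lower number from compound 2 to compound 4 (0.05 log units; within the scatter), the first step between measured compounds here that differ in one place. At this position, on an aromatic carbon para to a large group, the acetyl with its carbonyl is therefore not required for a measured number, as compound 4 gives 3880 nM. Nothing shown accounts for why the two compounds read alike.

Going by these compounds, whether an amine or a carboxylic acid on this same carbon would give a number beyond the scatter of compound 4 remains open, as one replacement by hydrogen cannot show how the position responds to other groups. Compound 1 and compound 3 each differ from compound 4 in more than one place, so they cannot settle this.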